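Aryl-ether variation in a thioether acid series

A few compounds are considered here, and "the series" means these few. Any claim that something is new, unique, unknown or untested is made for them only; others in the source may bear on it.

Compound 1 `CCCCC(Sc1ccc(OCCCOc2ccc(C)cc2)cc1)C(=O)O` stands at the higher of the two measured numbers, giving 5200 nM in an assay on isolated protein for inhibition of Polyunsaturated fatty acid 5-lipoxygenase (Homo sapiens), read by HPLC, with a stated time of 15 min, in the presence of a further agent that is not named here; on this read-out higher numbers stand for weaker inhibition and lower numbers for stronger inhibition. Compound 2 `CCCCC(Sc1ccc(OCCCOc2ccc(-c3ccccc3)cc2)cc1)C(=O)O` gives 900 nM in this assay. Among the measured compounds shown here, the single measured step, a 5.8-fold lower number from compound 1 to compound 2 (0.76 log units; beyond the scatter), is the only comparison available. Compound 3 `CCCCC(Sc1ccc(OCCCOc2cccc(C(C)C)c2)cc1)C(=O)O` differs from compound 1 by 3-isopropylphenyl in place of 4-methylphenyl on an oxygen on a saturated carbon. The change does not repeat the measured step, so only a modest shift in the same direction, possibly within the scatter, is expected in this assay. Compound 3 is estimated at 2600 nM, with a range of 900 nM to 7000 nM. That expectation corresponds to a 2.0-fold lower number from compound 1 to compound 3 (0.30 log units; within the scatter).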

Compound 3, half-maximal inhibitory concentration: 1400 nM
Compound 3: middle estimate off by 1.9-fold (0.27 log units), on the high side; measured number inside the range.
By their numbers in this assay, from the lowest: compounds 2 and 3 (each within the scatter of the next); then compound 1.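

The change from 4-methylphenyl to 3-isopropylphenyl gives a 3.7-fold lower number from compound 1 to compound 3 (0.57 log units; beyond the scatter) in this assay, so a second replacement at this position, with no added hydrogen-bond donors or acceptors, also lowers the number. Compound 2 and compound 3 lie within the scatter of each other, although their groups differ. Nothing available accounts for this step. The change alters both the alkyl group and its place on the ring, and the compounds shown do not separate these two effects. From the compounds shown here alone, how an amine or a carboxylic acid on this ring would read remains open.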